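Allylation of the Remaining Phenol in a Curcuminoid Series

The compounds below may be only part of what the source reports. "The series", "measured", "known", "first", "only" and "open" are said of these compounds alone.

The study concerns a cytotoxicity read-out in an ADME assay on HEK293 cells (Homo sapiens) for cytotoxicity, read by resazurin assay, with a stated time of 16 h (a lower number here means that less compound is needed, a higher number that more compound is needed for the effect), on two diaryl dienone compounds, with a third awaiting measurement. Compound 1 `O=C(/C=C/c1ccc(O)cc1)CC(=O)/C=C/c1ccc(O)c(O)c1` carries free hydroxy groups on both aromatic rings, and in this assay compound 1 gives 30000 nM. Compound 2 `C=CCOc1ccc(/C=C/C(=O)CC(=O)/C=C/c2ccc(O)c(OC)c2)cc1OC` has methoxy groups on both rings, an allyloxy group on one ring and a hydroxy group on the other; in this assay compound 2 gives 270000 nM. Compound 2 therefore stands at the highest of the two numbers, and its value lies beyond the usual scatter from that of compound 1.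

Compound 3 `C=CCOc1ccc(/C=C/C(=O)CC(=O)/C=C/c2ccc(OCC=C)c(OC)c2)cc1OC` follows from compound 2 by one change: allyl in place of hydrogen on an oxygen on an aromatic ring. For the measured compounds named here, no measured step of this kind exists among the compounds here, so the expectation rests on compound 2 alone. A small step upward, or none beyond the scatter, is expected for this assay, given that compound 2 already gives 270000 nM. The step from compound 2 to compound 3 is estimated as a 1.3-fold higher number from compound 2 to compound 3 (0.11 log units; within the scatter). Compound 3 is expected to give about 350000 nM, between 150000 nM and 800000 nM.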

Compound 3, half-maximal effective concentration: > 500000 nM
Compound 3: no number, only a limit; the forecaster's own chance of this, stated with the estimate: 25%; at least 1.4-fold (0.15 log units) between middle value and limit.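

Hydroxy to allyloxy, on an oxygen on an aromatic ring, is the first change here that can be read as a single step: in this assay it amounts to an at least 1.8-fold higher number from compound 2 to compound 3 (0.26 log units; that floor lies within the scatter). The entry for compound 3, > 500000 nM, is a limit of the assay and not a number, so only the lower end of this step is known, and that end alone does not carry it beyond the scatter. On these data alone, the true size of the step therefore stays unknown, and the data show only how far it reaches at the least, with compound 3 standing at the end of the reported range: the limit of > 500000 nM in this assay, at which 1 of the 3 values shown sits.

For the compounds shown here, compound 1 and compound 2 differ in more than one place, so the step between them cannot be read, and the allyl change remains the only single change available in this set. As far as these compounds go, whether any other group on this oxygen, such as a methyl ether, a longer chain like propyl, or a chain ending in an amine or a carboxylic acid, would behave as allyl does remains open.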